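Methyl in place of hydrogen across two cores

This account rests on a few compounds, and the source may have more. Where it says the series, first, only, none or still open, it means among the compounds named here.

Measured in a toxicity assay on the whole organism with Rattus norvegicus as the target, at a dose of 100 mg/kg by the oral route; a lower number here means a weaker effect, a higher number a stronger effect of the compound at the dose given:
compound 1, `Clc1ccc(OCC2=NCCO2)cc1`: 10%
compound 2, `Cc1ccccc1OCC1=NCCO1`: 10%
compound 3, `Cc1cc(OCC2=NCCO2)ccc1Cl`: 20%

Compound 1 and compound 3 differ in one place, (methyl in place of hydrogen on an aromatic carbon), and in this assay the step is a number 10 percentage points higher from compound 1 to compound 3 (within the scatter). Compound 2 carries a different core; the difference between the two cores is not broken down here. Its read-out in this assay is level with that of compound 1 at the digits given, and together they are the lowest of the three numbers, while compound 3 lies higher by an amount still within the scatter. No ordering is claimed among the three.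

Compound 4, `Cc1ccc(OCC2=NCCO2)c(C)c1`, is not yet measured. It differs from compound 2 by methyl in place of hydrogen on an aromatic carbon. Among the measured compounds shown here, this is the same kind of change as the one from compound 1 to compound 3, but the surroundings differ: in compound 3 the entering methyl sits ortho to a chloro group and meta to a group of 7 heavy atoms, whereas in compound 4 it sits meta to a methyl group and para to a group of 7 heavy atoms.

For the measured compounds named here, with only one measured instance of this change, the expectation rests on that single step. For compound 4 in this assay the expected step is a number 5 percentage points higher from compound 2 to compound 4 (within the scatter), beside the measured a number 10 percentage points higher from compound 1 to compound 3 (within the scatter). Compound 4 is thus estimated at 15%, with a plausible range from 5% to 30%.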

Compound 4, a percentage reported as activity, at one dose (the size of the read-out at that dose, not a potency): 15%
Compound 4: middle estimate and measured number agree at the digits printed; the measured number falls inside the stated range.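

In this assay, methyl in place of hydrogen on an aromatic carbon can now be read on two cores, and the new step is a number 5 percentage points higher from compound 2 to compound 4 (within the scatter). Set beside the earlier step, the two instances do not separate: the same change on two cores in this assay, a number 10 percentage points higher (within the scatter) from compound 1 to compound 3 and a number 5 percentage points higher (within the scatter) from compound 2 to compound 4, 5 percentage points apart, within the scatter of two such steps. This shows that the change behaves alike on the core of compound 1 and the core of compound 2 as far as this read-out can tell, even though in compound 4 the entering methyl sits meta to a methyl group and para to a group of 7 heavy atoms; it does not show a shared effect of any definite size, since neither step stands clear of the scatter, and two pairs of compounds give no rule for the whole series.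

The compounds shown leave open whether another group in the same place, such as an amine, a carboxylic acid or a longer chain, would give a step beyond the scatter in this assay. They also leave open whether the agreement between the two cores would hold for a change that produces a clearly readable step, since so far the comparison rests on small steps alone.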